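The compounds below may be only part of what the source reports. "The series", "measured", "known", "first", "only" and "open" are said of these compounds alone.

Compound 1 `Cc1nc(C(=O)Nc2ccc(Cl)c(-c3nnc4c(Cl)cccn34)c2)cs1`: in a functional assay on HeLa cells (Homo sapiens) for antiproliferative activity, read by MTT assay, with a stated time of 72 h (on this read-out lower numbers stand for stronger inhibition and higher numbers for weaker inhibition), compound 1 gives 79800 nM.
Compound 2 `O=C(Nc1ccc(Cl)c(-c2nnc3c(Cl)cccn23)c1)c1ccc(Cl)cc1`: in this assay compound 2 gives > 100000 nM, which is a limit of the assay and not a number.
Compound 3 `CS(=O)(=O)c1ccc(C(=O)Nc2ccc(Cl)c(-c3nnc4c(Cl)cccn34)c2)cc1`: in this assay compound 3 gives > 100000 nM, again a limit of the assay.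

Compound 3 thus stands at the limit rather than at a number, namely (the limit of > 100000 nM in this assay, at which 2 of the 3 values shown sit), and nothing below that limit is read for it. Compound 4 `Cc1cc(Cl)ccc1C(=O)Nc1ccc(Cl)c(-c2nnc3c(Cl)cccn23)c1` differs from compound 3 in one place: 4-chloro-2-methylphenyl in place of 4-(methylsulfonyl)phenyl on a carbonyl carbon. Among the compounds with values here, two measured steps bear on this change. The step that the two limits leave unreadable from compound 2 to compound 3 runs over the same pair of groups in the opposite direction, compound 2 carrying the 4-chlorophenyl and compound 4 the 4-chloro-2-methylphenyl on the same carbonyl carbon, and its size cannot be read from two limits. The step of an at least 1.2-fold higher number from compound 1 to compound 2 (0.09 log units; that floor lies within the scatter) shows that the 4-chlorophenyl amide already sits at the limit. Within the data shown here, no measured compound carries the added methyl, and no step tells its effect. Compound 4 is therefore expected to stay close to the limit, with the step of a number no higher from compound 3 to compound 4 (the limit leaves the size open) expected to lie within the scatter. The estimate for compound 4 in this assay is 100000 nM, with a range from 40000 nM to 300000 nM.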

Compound 4, half-maximal inhibitory concentration: > 100000 nM
Compound 4: only a limit was reported; the forecaster's own chance of this, stated with the estimate: 60%; the middle value lies on the limit itself.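

In this assay compound 4 gives > 100000 nM, which is a limit of the assay and not a number. The 4-chloro-2-methylphenyl group on this carbonyl carbon thus joins the 4-chlorophenyl group of compound 2 and the 4-(methylsulfonyl)phenyl group of compound 3, which leaves compound 1, with its 2-methyl-1,3-thiazol-4-yl group, as the only compound shown that gives a number: the limit of > 100000 nM in this assay, at which 3 of the 4 values shown sit. The only readable step is an at least 1.2-fold higher number from compound 1 to compound 4 (0.09 log units; that floor lies within the scatter), and the steps linking compound 2, compound 3 and compound 4 to one another cannot be read.

The compounds shown leave open whether any phenyl group on this carbonyl carbon can give a number in this assay, what the added methyl of compound 4 does, and whether the number of compound 1 belongs to the thiazole ring or to its methyl. A 1,3-thiazol-4-yl group without that methyl, a pyridine ring, or a phenyl ring bearing an amine or a carboxylic acid would bear on these questions.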